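Carbamoyl in Place of Isopropyl on Two Related Cores

A few compounds are considered here, and "the series" means these few. Any claim that something is new, unique, unknown or untested is made for them only; others in the source may bear on it.

Measured compounds:
compound 1, `NC(=O)C[C@H](NC(=O)CN(c1ncnc2c1ncn2C1CCCCO1)C1CC1)C(=O)OCc1ccccc1`, 34.5%
compound 2, `CC(C)C[C@H](NC(=O)CN(c1nc(Cl)nc2[nH]cnc12)C1CC1)C(=O)OCc1ccccc1`, 33.9%
compound 3, `CC(C)C[C@H](NC(=O)CN(c1ncnc2c1ncn2C1CCCCO1)C1CC1)C(=O)OCc1ccccc1`, 26.2%

The three compounds were tested in a functional assay on the whole organism (Tail, strain ICR) with Mus musculus as the target, in the tail flick test, with a stated time of 30 min, at a dose of 25 umol/kg by the oral route; a lower number here means a weaker effect, a higher number a stronger effect of the compound at the dose given. Compound 1 gives 34.5%, compound 2 gives 33.9%, and compound 3 gives 26.2%. The three numbers lie close together, and none of the gaps between them is beyond the scatter, so no order among them can be read from these data.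

Compound 1 and compound 3 share one core and differ in a single place: carbamoyl in place of isopropyl on a saturated chain carbon, two bonds along the chain from an amide-type nitrogen and a carbonyl carbon. This change made a step of a number 8.3 percentage points higher from compound 3 to compound 1 (within the scatter), which is within the scatter.

Compound 2 carries a different core; the difference between the two cores is not broken down here. Compound 4, `NC(=O)C[C@H](NC(=O)CN(c1nc(Cl)nc2[nH]cnc12)C1CC1)C(=O)OCc1ccccc1`, has not yet been measured in this assay. It stands to compound 2 as compound 1 stands to compound 3: carbamoyl in place of isopropyl on a saturated chain carbon, two bonds along the chain from an amide-type nitrogen and a carbonyl carbon. The place is the same in both pairs, so this is the same change on a second core.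

The expectation for compound 4 rests on compound 3 and the step of a number 8.3 percentage points higher from compound 3 to compound 1 (within the scatter) that this change made once before. On that basis the step from compound 2 to compound 4 is expected to be a number 6.1 percentage points higher from compound 2 to compound 4 (within the scatter), a small one. Compound 4 is therefore estimated at 40% in this assay, with a likely range of 26% to 54%.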

Compound 4, a percentage reported as activity, at one dose (the size of the read-out at that dose, not a potency): 24.4%
Estimate against measurement, compound 4: 15.6 percentage points above; measured number below the stated range.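

In this assay, carbamoyl in place of isopropyl on the second core gave a step of a number 9.5 percentage points lower from compound 2 to compound 4 (within the scatter), and taken alone, neither this step nor the earlier one on the first core can be told from the usual variation between repeated measurements. Set side by side, however, the two steps do differ, so in this series the change cannot be assumed to carry the same size or direction from the core of compound 3 to the core of compound 2: the same change on two cores in this assay, a number 8.3 percentage points higher (within the scatter) from compound 3 to compound 1 and a number 9.5 percentage points lower (within the scatter) from compound 2 to compound 4, 17.8 percentage points apart, beyond the scatter of two such steps This shows that the effect of the change depends on the core in these two pairs, but it does not show which feature of the cores is responsible, since their difference is not broken down here, and it does not show that carbamoyl in itself raises or lowers the read-out on either core.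

The compounds shown leave open whether a carboxylic acid, an amine or a longer chain at the same place would also behave differently on the two cores. They also leave open whether the contrast between the two pairs would persist at another dose or another time point.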